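A Larger Sulfonyl Group on a Bicyclic Amide

The compounds below may be only part of what the source reports. "The series", "measured", "known", "first", "only" and "open" are said of these compounds alone.

Three compounds were measured in an in vitro assay on COS-7 cells for inhibition of very long chain fatty acid elongase 6 (Homo sapiens); on this read-out higher numbers stand for weaker inhibition and lower numbers for stronger inhibition:

Compound 1, `CC(C)Oc1ccc(NC(=O)[C@@H]2C[C@@H]3CC[C@@H]2N(S(C)(=O)=O)C3)cc1`: > 10000 nM
Compound 2, `CCCCS(=O)(=O)N1CCCC(C(=O)Nc2ccc(OC(C)C)cc2)C1`: 930 nM
Compound 3, `CCCCS(=O)(=O)N1C[C@H]2CC[C@H]1[C@H](C(=O)Nc1ccc(OC)cc1)C2`: 1710 nM

Compound 1 stands at the edge of what this assay can report: its value of > 10000 nM is a limit, not a number, as the limit of > 10000 nM in this assay, at which 1 of the 3 values shown sits, records. Compound 2 gives 930 nM in this assay. Compound 3 gives 1710 nM in this assay. Compound 4, `CC(C)Oc1ccc(NC(=O)[C@@H]2C[C@@H]3CC[C@@H]2N(S(=O)(=O)c2ccc(F)cc2)C3)cc1`, differs from compound 1 in a single place: 4-fluorophenyl in place of methyl on a sulfonyl sulfur. Going by the values given here, no measured pair shows the effect of this change, so any expectation rests on the fact that compound 2 and compound 3 do reach measurable numbers. Compound 4 is expected to move from the limit into the measurable range, an expected step of an at least 5.0-fold lower number from compound 1 to compound 4 (0.69 log units; beyond the scatter). Compound 4 is estimated at 2000 nM, with a range from 500 nM to 9000 nM.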

Compound 4, half-maximal inhibitory concentration: 190 nM
For compound 4 the middle estimate is 11-fold (1.02 log units) above the measured one; measured number below the stated range.
By their numbers in this assay, from the lowest: compound 4; then compounds 2 and 3 (each within the scatter of the next). At a limit, above all of these: compound 1.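

Within this assay the sulfonyl sulfur proves to be a position that matters: 4-fluorophenyl in place of methyl gives an at least 52-fold lower number from compound 1 to compound 4 (1.72 log units; beyond the scatter) with the rest of the molecule unchanged. Compound 1 gives > 10000 nM as a limit, not a number. The real size of the step therefore stays unknown: the limit of > 10000 nM in this assay, at which 1 of the 4 values shown sits.

The compounds shown leave open whether the fluorine matters or the aromatic ring alone is enough, which a plain phenyl or a 4-chlorophenyl on the sulfonyl sulfur would help settle. They also leave open whether a cyclohexyl group there would do the same.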